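A few compounds are considered here, and "the series" means these few. Any claim that something is new, unique, unknown or untested is made for them only; others in the source may bear on it.

Compound 1, with structure `COC(=O)[C@@]1(C)CCC=C2[C@@H]1CC[C@@H](C)[C@]2(C)Cc1c[nH]c2ccc(OC)cc12`, was tested in a functional assay on HBL-100 cells (Homo sapiens) for inhibition, read by sulforhodamine B assay, with a stated time of 48 h (on this read-out lower numbers stand for stronger inhibition of growth and higher numbers for weaker inhibition of growth), and gave 2100 nM. Compound 2, `COC(=O)[C@@]1(C)CCC=C2[C@@H]1CC[C@@H](C)[C@]2(C)Cc1c(C)[nH]c2ccc(OC)cc12`, differs from it by methyl in place of hydrogen on an aromatic carbon, the methyl sitting on an aromatic carbon of a five-membered aromatic ring with one nitrogen, next to the ring nitrogen and next to the ring atom that bears a large group. In this assay compound 2 gave 16000 nM, so the change made a 7.6-fold higher number from compound 1 to compound 2 (0.88 log units; beyond the scatter). Compound 3, `COC(=O)[C@@]1(C)CC[C@@H]2C3=C1CC[C@@H](C)[C@]3(C)Cc1c2[nH]c2ccccc12`, has a different core; how its core and that of compound 1 differ is not broken down here. In this assay compound 3 gave 3500 nM, close to compound 1 and clearly apart from compound 2. Compound 4, `COC(=O)[C@@]1(C)CC[C@@H]2C3=C1CC[C@@H](C)[C@]3(C)Cc1c2[nH]c2c(C)cccc12`, differs from compound 3 by methyl in place of hydrogen on an aromatic carbon, but here the methyl sits on an aromatic carbon of a six-membered aromatic ring of carbon only, ortho to a fused ring and meta to a fused ring, so this is the same kind of change, not the same one. Because the earlier step of a 7.6-fold higher number from compound 1 to compound 2 (0.88 log units; beyond the scatter) weakened inhibition at a different place, a smaller step of a 1.7-fold higher number from compound 3 to compound 4 (0.23 log units; within the scatter) is expected from compound 3 to compound 4. Compound 4 is estimated at 6000 nM, between 2500 nM and 15000 nM.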

Compound 4, concentration for 50% growth inhibition: 13000 nM
The estimate for compound 4 lay 2.2-fold (0.34 log units) below the measured number; the range from low to high includes it.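

In this assay, methyl in place of hydrogen on an aromatic carbon gave a higher number on the second core as well, a 3.7-fold higher number from compound 3 to compound 4 (0.57 log units; beyond the scatter), so on both cores the change went with weaker inhibition of growth, and the two steps do not differ in size beyond the scatter: the same change on two cores in this assay, a 7.6-fold higher number (0.88 log units; beyond the scatter) from compound 1 to compound 2 and a 3.7-fold higher number (0.57 log units; beyond the scatter) from compound 3 to compound 4, 2.1-fold (0.31 log units) apart, within the scatter of two such steps. Among these compounds, each core offers only one pair, however, and the methyl sits on a five-membered aromatic ring with one nitrogen in compound 2 but on a six-membered aromatic ring of carbon only in compound 4, so these are the same kind of change at different places. The two steps therefore do not show that a methyl at one given place carries over from one core to the other, and they do not explain why growth inhibition weakens.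

Still open, from the compounds shown here alone, is how a methyl would behave at the same place on both cores. Going by these compounds, it is also open whether a larger or different group, such as ethyl, a fluorine atom or an amine, would follow the same course.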